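A few compounds are considered here, and "the series" means these few. Any claim that something is new, unique, unknown or untested is made for them only; others in the source may bear on it.

Compound 3 `C[S+]([O-])c1ccc(CNC(=O)c2ccc(C(C)(C)C)cc2)cc1` stands second highest of the three numbers in an assay on HeLa cells with Bile acid receptor (Homo sapiens) as the target, read by a luciferase reporter, with a stated time of 24 h (a higher number here means that more compound is needed for the effect, a lower number that less compound is needed), giving 1300 nM; compound 2 `O=C(O)c1ccc(CNC(=O)c2cccc(-c3ccccc3)c2)cc1` gives 670 nM, within the scatter of compound 3, while compound 1 `CC(C)(C)c1ccc(C(=O)NCc2ccc(C(N)=O)cc2)cc1` gives 3800 nM, beyond it. Compound 4 `CC(C)(C)c1ccc(C(=O)NCc2ccc(OC(F)(F)F)cc2)cc1` differs from compound 3 by a group of 5 heavy atoms (1 carbon, 1 oxygen, 3 fluorine; no ring) in place of a group of 3 heavy atoms (1 carbon, 1 oxygen, 1 sulfur; no ring), on an aromatic carbon. Within the data shown here, no measured compound carries a trifluoromethoxy group, so no step bears directly on this change. Among the measured compounds shown here, the one step at the same aromatic carbon is a 2.9-fold lower number from compound 1 to compound 3 (0.47 log units; beyond the scatter), a modest shift. With nothing closer to lean on, a change no larger than the scatter is expected in this assay from compound 3 to compound 4, in either direction. Compound 4 is therefore estimated at 1500 nM in this assay, between 400 nM and 6000 nM, which would mean a 1.2-fold higher number from compound 3 to compound 4 (0.06 log units; within the scatter).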

Compound 4, half-maximal effective concentration: 160 nM
The estimate for compound 4 lay 9.4-fold (0.97 log units) above the measured number, and the stated range ends above it.
By their numbers in this assay, from the lowest: compound 4; then compounds 2 and 3 (each within the scatter of the next); then compound 1.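

In this assay, among these compounds, the group on this aromatic carbon, para to a large group, proves able to move the number further than the earlier compounds showed: there is an 8.1-fold lower number from compound 3 to compound 4 (0.91 log units; beyond the scatter), and with trifluoromethoxy in place of carbamoyl there is a 24-fold lower number from compound 1 to compound 4 (1.38 log units; beyond the scatter). With the shared core held constant, the three groups on this carbon give three numbers, each beyond the scatter of the others. No measured evidence here explains the gain. The compounds shown leave open whether the oxygen or the fluorines of trifluoromethoxy carry the change, which a methoxy group and a trifluoromethyl group on the same carbon would separate.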